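The source may report more compounds than this note shows. Statements on the series, on what has been measured and on what is new or still open speak of the compounds shown alone.

Compound 2, `C[C@@H](C#Cc1cccc(C(=O)NCc2ccccc2C(F)(F)F)c1)N(O)C(N)=O`, gives 700 nM in an assay for inhibition of Polyunsaturated fatty acid 5-lipoxygenase (Homo sapiens), read by HPLC, with stated times of 15 min and 10 min (a lower number here means a stronger inhibitor, a higher number a weaker inhibitor), the highest number among the three measured compounds. Compound 3, `C[C@H](C#Cc1cccc(C(=O)NCCC(c2ccc(F)cc2)c2ccc(C(F)(F)F)cc2)c1)N(O)C(N)=O`, gives 220 nM, and compound 1, `C[C@H](C#Cc1cccc(C(=O)NCCC(c2ccccc2)c2ccc(Cl)c(Cl)c2)c1)N(O)C(N)=O`, gives 96 nM; both lie beyond the scatter from compound 2. Within the data shown here, compound 4, `C[C@H](C#Cc1cccc(C(=O)NCc2ccccc2C(F)(F)F)c1)N(O)C(N)=O`, has not yet been measured. the two compounds have the same atoms and bonds and differ only in configuration as drawn: 1 of 1 stereo elements differ; a stereocentre at a saturated chain carbon is drawn S in compound 2 and R in compound 4 Compounds 1 and 3, which give the lower numbers, are drawn with the same configuration as compound 4, although they also carry different amide portions, so no step between measured compounds isolates the stereocentre. With that caveat, compound 4 is expected to give a lower number than compound 2, by a step of a 2.0-fold lower number from compound 2 to compound 4 (0.30 log units; within the scatter) that could fall within the scatter or somewhat beyond it. The estimate for compound 4 is 350 nM, with a range from 100 nM to 1500 nM.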

Compound 4, half-maximal inhibitory concentration: 600 nM
Compound 4: the middle estimate sits 1.7-fold (0.23 log units) below what was measured; low and high end bracket the measured number.
By their numbers in this assay, from the lowest: compound 1; then compound 3; then compounds 4 and 2 (each within the scatter of the next).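

Among these compounds, the step of a 1.2-fold lower number from compound 2 to compound 4 (0.07 log units; within the scatter) is the first to isolate the stereocentre at the saturated chain carbon. With the amide portion shared by these two compounds, drawing this centre S or R leaves the numbers within the scatter of each other. The comparison bears on configuration alone for one reason: the fact that compounds 2 and 4 differ only in the configuration as drawn

From the compounds shown here alone, whether this holds with the larger amide portions of compound 1 and compound 3 stays open, as neither has a counterpart of opposite configuration here. Also open, going by these compounds, is how a carboxylic acid or an amine in place of the trifluoromethyl would read.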